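Swapping a fluorophenyl for pyrimidinyl on the piperidine core

This account rests on a few compounds, and the source may have more. Where it says the series, first, only, none or still open, it means among the compounds named here.

Compound 1 `COc1cc(C(F)(F)F)cc(C(F)(F)F)c1C(=O)NC1(c2ccccc2)CCCN(C(=O)c2ccccc2)C1`; compound 2 `COc1cc(C(F)(F)F)cc(SC)c1C(=O)NC1(c2cccc(F)c2)CCCN(C)C1`.

In an assay on cells for inhibition of sodium- and chloride-dependent glycine transporter 1 (Homo sapiens) (on this read-out higher numbers stand for an effect only at larger amounts of compound and lower numbers for an effect already at smaller amounts), compound 1 gives only a limit, > 10000 nM, and no number. Among the compounds with values here, compound 2 is the one compound with a number: in this assay compound 2 gives 48 nM. Compound 3 `COc1cc(C(F)(F)F)cc(SC)c1C(=O)NC1(c2ccncn2)CCCN(C)C1` has not been measured; it differs from compound 2 in one place: pyrimidin-4-yl in place of 3-fluorophenyl on a saturated ring carbon. Within the data shown here, no measured pair shows the effect of this change, so the expectation rests on compound 2 alone. The step from compound 2 to compound 3 is expected to weaken the effect beyond the usual scatter, a 4.2-fold higher number from compound 2 to compound 3 (0.62 log units; beyond the scatter). Compound 3 is estimated at 200 nM, between 60 nM and 800 nM.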

Compound 3, half-maximal effective concentration: 1700 nM
Compound 3: the middle estimate sits 8.5-fold (0.93 log units) below what was measured, and the stated range ends below it.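

At this saturated ring carbon, the aromatic ring cannot be exchanged freely: in this assay, pyrimidin-4-yl in place of 3-fluorophenyl gives a 35-fold higher number from compound 2 to compound 3 (1.55 log units; beyond the scatter). Keeping a six-membered aromatic ring is therefore not enough to hold the effect, so the identity of the ring matters here. Nothing shown accounts for the size of this step.

Going by these compounds, it remains open whether the step follows from losing the fluorine or from gaining the ring nitrogens. A pyridinyl group, with a single ring nitrogen, at this place would help separate the two.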